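A few compounds are considered here, and "the series" means these few. Any claim that something is new, unique, unknown or untested is made for them only; others in the source may bear on it.

In a functional assay on HPAC cells (Homo sapiens) for inhibition, read by MTT assay, with a stated time of 72 h (a higher number here means a weaker inhibitor of growth, a lower number a stronger inhibitor of growth), compound 3 `CN(CCCNS(=O)(=O)c1cc(C(F)(F)F)cc(C(F)(F)F)c1)Cc1ccccc1` gives 30000 nM. That is the highest of the three numbers shown, though compound 1 `O=S(=O)(NCCNCc1cccc2ccccc12)c1cc(C(F)(F)F)cc(C(F)(F)F)c1` is close to it: in this assay compound 1 gives 18000 nM, and the two values lie within the usual scatter of one another. Compound 2 `O=S(=O)(NCCNCc1ccc(-c2ccccc2)cc1)c1cc(C(F)(F)F)cc(C(F)(F)F)c1` stands apart, since in this assay compound 2 gives 2800 nM, a number well beyond the scatter from that of compound 3.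

Compound 4 `O=S(=O)(NCCCNCc1ccc(Cl)cc1)c1cc(C(F)(F)F)cc(C(F)(F)F)c1` has not yet been measured. It differs from compound 3 by a single change: (4-chlorobenzyl)amino in place of benzyl(methyl)amino on a saturated chain carbon, three bonds along the chain from a sulfonamide nitrogen. The group that enters carries one hydrogen-bond donor where the group that leaves carried none. Among the measured compounds shown here, no measured pair of compounds differs by exactly this change, so the size of the step has to be judged from the three values alone. For the measured compounds named here, compound 2, the only compound among the three with a value beyond the scatter from compound 3, also carries a secondary amine; but it differs from compound 3 in more than one place, so it only loosely guides the expectation.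

On that basis, a modest move towards a lower number is expected, a 3.3-fold lower number from compound 3 to compound 4 (0.52 log units; beyond the scatter). For compound 4 the estimate in this assay is 9000 nM, with a range from 2500 nM to 30000 nM.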

Compound 4, concentration for 50% growth inhibition: 2800 nM
Beside the measured number, compound 4's estimate is 3.2-fold (0.51 log units) above it; low and high end bracket the measured number.
By their numbers in this assay, from the lowest: compounds 2 and 4 (each within the scatter of the next); then compounds 1 and 3 (each within the scatter of the next).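

In this assay the exchange of benzyl(methyl)amino for (4-chlorobenzyl)amino on a saturated chain carbon, three bonds along the chain from a sulfonamide nitrogen, gives an 11-fold lower number from compound 3 to compound 4 (1.03 log units; beyond the scatter) and is the only single change read so far among these compounds. It shows that this position is sensitive to what it carries: the groups that leave and enter both hold 9 heavy atoms and one six-membered aromatic ring, yet the step is large. The change joins a chlorine with a hydrogen-bond donor where the leaving group had none, and nothing measured here explains the size of the step.

The compounds shown do not separate these two parts of the change, and the plain benzylamino group and the (4-chlorobenzyl)(methyl)amino group would each isolate one of them. Also open, going by these compounds, is whether a 4-fluorobenzyl or 4-methoxybenzyl group on the amine, or a longer chain between the sulfonamide nitrogen and the amine, would hold the lower number seen for compound 4 at 2800 nM in this assay.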